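This account rests on a few compounds, and the source may have more. Where it says the series, first, only, none or still open, it means among the compounds named here.

Compound 1 `COc1cncc(C2=CC3CC(C2)CN(C)C3)c1` gives 19% in an in vitro functional assay on SH-EP1 cells for agonist activity at Neuronal acetylcholine receptor; alpha4/beta2 (Homo sapiens), read by FLIPR and calcium flux (on this read-out higher numbers stand for larger maximal responses and lower numbers for smaller maximal responses), the lower of the two measured numbers; compound 2 `COc1cncc(C2=CC3CNCC(C2)C3)c1` gives 72%, and the change a number 53 percentage points higher from compound 1 to compound 2 (beyond the scatter) concerns hydrogen in place of methyl on an amine nitrogen in a ring. Compound 3 `CC(C)Oc1cncc(C2=CC3CC(C2)CN(C)C3)c1` differs from compound 1 elsewhere: isopropyl in place of methyl on an oxygen on an aromatic ring. Among the compounds with values here, no measured step touches the oxygen on the aromatic ring, so nothing measured bears on this change; the expected step of a number 6 percentage points higher from compound 1 to compound 3 (within the scatter) is therefore kept small, with no direction beyond the scatter claimed. Compound 3 is estimated at 25%, in a range from 5% to 55%.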

Compound 3, largest response reached (reported as percent of maximum), in percent of the reference or control that the assay uses: 1%
For compound 3 the middle estimate is 24 percentage points above the measured one; the whole stated range lies above it.
By their numbers in this assay, from the lowest: compound 3; then compound 1; then compound 2.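

Notes on the series: the group on the oxygen on the aromatic ring matters in this assay, as methoxy to isopropoxy gives a number 18 percentage points lower from compound 1 to compound 3 (beyond the scatter). The maximal response therefore depends on this position as well as on the amine nitrogen in a ring, and here compound 3 retains only 1%. Nothing at hand explains this drop.

Open: whether ethyl on this oxygen gives a response between those of methyl and isopropyl, and whether isopropyl has the same effect on the core of compound 2, with hydrogen on the amine nitrogen.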